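The compounds below may be only part of what the source reports. "The series", "measured", "known", "first", "only" and "open" are said of these compounds alone.

For the measured compounds named here, compound 3 `Cc1ccc(OCC(=O)Nc2ccc(OCC(=O)O)c(F)c2)cc1` gives 31.2% in a functional assay on CHO cells for agonist activity at Free fatty acid receptor 1 (Homo sapiens), read by FLIPR, tested at 100 nM (a lower number here means a weaker effect, a higher number a stronger effect of the compound at the concentration tested), the highest of the three numbers so far. Compound 1 `O=C(O)COc1ccc(NC(=O)COc2ccccc2)cc1F` gives 29.8%, and the step of a number 1.4 percentage points higher from compound 1 to compound 3 (within the scatter) lies within the scatter, so these two cannot be ordered against each other. Compound 2 `Cc1ccccc1OCC(=O)Nc1ccc(OCC(=O)O)c(F)c1` gives 20.8%; the step of a number 10.4 percentage points higher from compound 2 to compound 3 (beyond the scatter) is beyond the scatter, whereas a number 9 percentage points lower from compound 1 to compound 2 (within the scatter) is not.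

The next compound, compound 4 `CC(C)c1ccc(OCC(=O)Nc2ccc(OCC(=O)O)c(F)c2)cc1`, differs from compound 3 in one place: isopropyl in place of methyl on an aromatic carbon. Going by the values given here, the one measured step that bears on it sits at the same position, where a number 1.4 percentage points higher from compound 1 to compound 3 (within the scatter) put methyl in place of hydrogen and moved nothing beyond the scatter. Among the compounds with values here, compound 4 continues at that aromatic carbon with isopropyl in place of methyl; no measured step tests a group larger than methyl there. The contrast a number 10.4 percentage points higher from compound 2 to compound 3 (beyond the scatter) concerns 4-methylphenyl in place of 2-methylphenyl and gives no guide to compound 4.

On that basis the step of a number 1.8 percentage points higher from compound 3 to compound 4 (within the scatter) is expected to remain within the scatter, if anything slightly upward. Compound 4 is therefore estimated at 33% in this assay, with a range from 20% to 46%.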

Compound 4, a percentage reported as activity, at one concentration (the size of the read-out at that concentration, not a potency): 11.8%
Beside the measured number, compound 4's estimate is 21.2 percentage points above it; the whole stated range lies above it.
By their numbers in this assay, from the lowest: compounds 4, 2, 1 and 3 (each within the scatter of the next, the first and the last beyond it).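

Size at this aromatic carbon, para to a large group, matters in this assay once it goes past methyl: isopropyl in place of methyl gives a number 19.4 percentage points lower from compound 3 to compound 4 (beyond the scatter) and so ends the flat picture left by methyl in place of hydrogen (a number 1.4 percentage points higher from compound 1 to compound 3 (within the scatter)). Isopropyl in place of hydrogen gives a number 18 percentage points lower from compound 1 to compound 4 (beyond the scatter) as well, so the loss stands against the unsubstituted compound too and is not merely a loss relative to methyl; among hydrogen, methyl and isopropyl at this carbon, only isopropyl separates from the others beyond the scatter. Nothing available here accounts for this drop.

Going by these compounds, with only these three groups at this carbon, it remains open where between methyl and isopropyl the loss sets in, and whether an ethyl, a methoxy, a chlorine or a trifluoromethyl would hold the level of compound 3 or fall with compound 4. The read-out is also the size of the effect at a single concentration, which leaves open whether compound 4 differs from compound 3 in potency, in the maximal response or in both.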